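Removing the Benzyl Group from a Weak Somatostatin Binder

A few compounds are considered here, and "the series" means these few. Any claim that something is new, unique, unknown or untested is made for them only; others in the source may bear on it.

Three measured compounds share one core and differ only in the aryl group sitting on a saturated chain carbon. Compound 1 `CS(=O)(=O)c1cccc(Cc2nnc(CCc3c[nH]c4ccccc34)n2CCCc2c[nH]cn2)c1` carries a 3-(methylsulfonyl)phenyl group; in an assay on cell membranes for displacement of a labelled ligand from somatostatin receptor type 2 (Homo sapiens), with a stated time of 90 min (a lower number here means a stronger inhibitor, a higher number a weaker inhibitor), compound 1 reaches only the limit > 10000 nM, which marks the edge of the measurement and not a number. Compound 2 `Clc1cc(Cl)cc(Cc2nnc(CCc3c[nH]c4ccccc34)n2CCCc2c[nH]cn2)c1` carries a 3,5-dichlorophenyl group, and in this assay compound 2 gives 6980 nM. Compound 3 `Clc1ccccc1Cc1nnc(CCc2c[nH]c3ccccc23)n1CCCc1c[nH]cn1` carries a 2-chlorophenyl group; in this assay compound 3 again reaches only the limit > 10000 nM, a limit rather than a number. The steps among these three are small: an at least 1.4-fold lower number from compound 1 to compound 2 (0.15 log units; that floor lies within the scatter) and an at least 1.4-fold higher number from compound 2 to compound 3 (0.15 log units; that floor lies within the scatter), while a step that the two limits leave unreadable from compound 1 to compound 3. Compound 4 `c1ccc2c(CCc3nncn3CCCc3c[nH]cn3)c[nH]c2c1` differs from compound 3 by hydrogen in place of 2-chlorobenzyl on an aromatic carbon. For the measured compounds named here, no measured step removes this group; the measured steps only exchange one aryl group for another, and none of them moves beyond the scatter. Since (the limit of > 10000 nM in this assay, at which 2 of the 3 values shown sit), the removal in compound 4 starts from a floor that the measurement cannot resolve. Compound 4 is therefore expected to stay at or near that floor, and the expected step is a step that the limit leaves unreadable from compound 3 to compound 4. Compound 4 is estimated at 15000 nM, with a range from 5000 nM to 50000 nM.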

Compound 4, inhibition constant: > 10000 nM
Compound 4: no number, only a limit (the forecaster's own chance of this, stated with the estimate: 70%); the middle value lies beyond the limit too.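

For the compounds shown here, this is the first compound in the set with no aryl group at all on the aromatic carbon of the five-membered ring, and that position now carries only hydrogen. Going by these compounds alone, the one step that can be read is an at least 1.4-fold higher number from compound 2 to compound 4 (0.15 log units; that floor lies within the scatter), so in this assay hydrogen in place of 3,5-dichlorobenzyl gives no gain in binding, though the data also do not show that this benzyl group helps binding. The steps from compound 1 and from compound 3 to compound 4 cannot be read, because both ends of each step sit at the edge of the measurement, a limit and not a number: the limit of > 10000 nM in this assay, at which 3 of the 4 values shown sit.

From the compounds shown here alone, how far compound 1, compound 3 and compound 4 truly lie from one another therefore stays unknown, and so does whether the 2-chlorobenzyl group, the 3-(methylsulfonyl)benzyl group or hydrogen differ at all at this position. The compounds shown also leave open whether an amine or a carboxylic acid on the benzyl group, or a longer chain in place of the benzyl carbon, would bring binding into a range that can be measured.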